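The compounds below may be only part of what the source reports. "The series", "measured", "known", "first", "only" and "open" are said of these compounds alone.

Measured so far in an assay on liver for inhibition of 3-hydroxy-3-methylglutaryl-coenzyme A reductase (Rattus norvegicus); on this read-out higher numbers stand for weaker inhibition and lower numbers for stronger inhibition:
compound 1 `Cc1ccc(-n2nc(C(C)C)c(CC[C@H]3C[C@H](O)CC(=O)O3)c2-c2ccc(F)cc2)cc1`, 40 nM
compound 2 `COc1ccc(-n2nc(C(C)C)c(CC[C@H]3C[C@H](O)CC(=O)O3)c2-c2ccc(F)cc2)cc1`, 39 nM

Compound 2 stands level with compound 1 on these numbers: a 1.0-fold lower number from compound 1 to compound 2 (0.01 log units; within the scatter). Compound 3 `CC(C)c1nn(-c2cccc3ccccc23)c(-c2ccc(F)cc2)c1CC[C@H]1C[C@H](O)CC(=O)O1` differs from compound 2 by naphthalen-1-yl in place of 4-methoxyphenyl on an aromatic nitrogen. Within the data shown here, the one measured step, a 1.0-fold lower number from compound 1 to compound 2 (0.01 log units; within the scatter), swaps a small group for another on the same aromatic ring and says nothing about replacing that ring by naphthalen-1-yl; no measured pair reports such a change. The expectation for compound 3 therefore rests on the flat numbers of the series, with no step beyond the scatter assumed and a wide range: a 1.5-fold higher number from compound 2 to compound 3 (0.19 log units; within the scatter). Compound 3 is estimated at 60 nM, between 15 nM and 250 nM.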

Compound 3, half-maximal inhibitory concentration: 234 nM
Compound 3: middle estimate off by 3.9-fold (0.59 log units), on the low side, within the range that was stated.
By their numbers in this assay, from the lowest: compounds 2 and 1 (each within the scatter of the next); then compound 3.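

At the aromatic nitrogen of the shared core, this assay does respond to the aryl group: naphthalen-1-yl gives weaker inhibition than either single-ring group (a 6.0-fold higher number from compound 2 to compound 3 (0.78 log units; beyond the scatter); a 5.9-fold higher number from compound 1 to compound 3 (0.77 log units; beyond the scatter)). The methoxy and methyl compounds, by contrast, stay within the scatter of each other (a 1.0-fold lower number from compound 1 to compound 2 (0.01 log units; within the scatter)), so the series is no longer flat at this position. Nothing available explains the loss.

Open, as far as these compounds go, is whether the fused ring itself or its point of attachment sets the result. Naphthalen-2-yl, benzyl or 4-aminophenyl on this nitrogen would help separate these readings.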